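The compounds below may be only part of what the source reports. "The series", "measured", "known", "first", "only" and "open" are said of these compounds alone.

In an ADME assay on MT4 cells (Homo sapiens) for cytotoxicity, read by MTT assay, with a stated time of 5 days (a higher number here means that more compound is tolerated, a lower number that less compound is tolerated), compound 2 (`COc1cc2nc([S+]([O-])CC(=O)Nc3ccc(Cl)cc3)nc(Nc3c(Cl)cc(/C=C/C#N)cc3Cl)c2cc1OC`), with 4-chlorophenyl on an amide-type nitrogen, gives 14400 nM. Compound 1 (`COc1cc2nc([S+]([O-])CC(=O)Nc3ccccc3[N+](=O)[O-])nc(Nc3c(Cl)cc(/C=C/C#N)cc3Cl)c2cc1OC`) is reported only as a limit, > 199000 nM. Compound 3 (`COc1cc2nc([S+]([O-])CC(=O)Nc3ccccc3C#N)nc(Nc3c(Cl)cc(/C=C/C#N)cc3Cl)c2cc1OC`) is also reported only as a limit, > 206000 nM. The next change leads to compound 4 (`COc1cc2nc([S+]([O-])CC(=O)Nc3c(C)cc(C)cc3C)nc(Nc3c(Cl)cc(/C=C/C#N)cc3Cl)c2cc1OC`): 2,4,6-trimethylphenyl in place of 2-cyanophenyl on an amide-type nitrogen. Among the measured compounds shown here, two measured steps bear on it, both large: an at least 13-fold lower number from compound 1 to compound 2 (1.14 log units; beyond the scatter) and an at least 14-fold higher number from compound 2 to compound 3 (1.15 log units; beyond the scatter). The remaining one, a step that the two limits leave unreadable from compound 1 to compound 3, has no readable size. The entering 2,4,6-trimethylphenyl, like the 4-chlorophenyl of compound 2, carries neither nitrile nor nitro, so a large step to a lower number is expected in this assay, estimated as an at least 8.2-fold lower number from compound 3 to compound 4 (0.91 log units; beyond the scatter). For compound 4 the expected value is 25000 nM, with an estimated range of 6000 nM to 150000 nM.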

Compound 4, half-maximal cytotoxic concentration: 8870 nM
Estimate against measurement, compound 4: 2.8-fold (0.45 log units) above, within the range that was stated.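

In this assay, the change from 4-chlorophenyl to 2,4,6-trimethylphenyl on the amide-type nitrogen gives a 1.6-fold lower number from compound 2 to compound 4 (0.21 log units; within the scatter), so this assay does not tell the two groups apart. Against the groups carrying nitrile and nitro, the same position gives an at least 23-fold lower number from compound 3 to compound 4 (1.36 log units; beyond the scatter) and an at least 22-fold lower number from compound 1 to compound 4 (1.35 log units; beyond the scatter), both read against compounds known only as limits. The large gap therefore no longer rests on compound 2 alone, since a second group with neither nitrile nor nitro falls on the same side of it. On these data alone, how an aminophenyl or a phenyl bearing a carboxylic acid would read at this position remains open.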